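The compounds below may be only part of what the source reports. "The series", "measured", "known", "first", "only" and "open" are said of these compounds alone.

Working notes on the series. Compound 1 `c1ccc(-c2cnccn2)c(OCC2=NCCN2)c1` carries a pyrazin-2-yl on the shared core; in a functional assay for activation of Alpha-1B adrenergic receptor (Homo sapiens), read by calcium flux (a higher number here means that more compound is needed for the effect, a lower number that less compound is needed), compound 1 gives 631 nM. Of the two numbers in hand this is the highest; the nearest is compound 2 `c1ccc(-c2ccns2)c(OCC2=NCCN2)c1`, and in this assay compound 2 gives 12.6 nM, so that the step is a 50-fold lower number from compound 1 to compound 2 (1.70 log units; beyond the scatter). Compound 3 `Cc1csc(-c2ccccc2OCC2=NCCN2)n1` sits at a limit of this assay: compound 3 gives < 100000 nM, which is a limit and not a number (the limit of < 100000 nM in this assay, at which 1 of the 3 values shown sits). The step that the limit leaves unreadable from compound 1 to compound 3 therefore cannot be sized, and the same holds for a step that the limit leaves unreadable from compound 2 to compound 3.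

Compound 4 `Cc1cnsc1-c1ccccc1OCC1=NCCN1` is not yet measured. It differs from compound 1 thus: 4-methyl-1,2-thiazol-5-yl in place of pyrazin-2-yl on an aromatic carbon. Among the measured compounds shown here, the one readable step that bears on it is the exchange from compound 1 to compound 2, which brought in the same 1,2-thiazol-5-yl ring without the methyl and moved the number downward by a large amount; the methyl-bearing 1,3-thiazole of compound 3 offers no readable guide. For compound 4 a step of about the same size and direction is therefore expected in this assay, namely a 32-fold lower number from compound 1 to compound 4 (1.50 log units; beyond the scatter). For compound 4 the expected value in this assay is 20 nM, within a range from 4 nM to 120 nM.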

Compound 4, half-maximal effective concentration: < 100000 nM
Compound 4 was reported as a limit; the forecaster's own chance of this, stated with the estimate: 10%; the middle value does not contradict the limit.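

In this assay compound 4 gives < 100000 nM, which is a limit and not a number. No step linking compound 4 to compound 1, compound 2 or compound 3 can therefore be read: the limit of < 100000 nM in this assay, at which 2 of the 4 values shown sit.

The compounds shown leave open what methyl in place of hydrogen on an aromatic carbon does to the number, going from compound 2 to compound 4.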